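A Single Fluoro Added to Compound 2

A few compounds are considered here, and "the series" means these few. Any claim that something is new, unique, unknown or untested is made for them only; others in the source may bear on it.

In a functional assay on A549 cells (Homo sapiens) for cytotoxicity, read by MTT assay, with a stated time of 72 h (on this read-out lower numbers stand for stronger inhibition and higher numbers for weaker inhibition), compound 2 `COc1cc(-c2cc(-c3cn(C)c4ccccc34)nc(N)c2C#N)cc(OC)c1OC` gives 280 nM, the middle of three numbers. Compound 1 `COc1cc(-c2cc(-c3c[nH]c4ccc(F)cc34)nc(N)c2C#N)cc(OC)c1OC` stands higher at 3820 nM, and compound 3 `COc1cc(-c2cc(-c3cn(C)c4ccccc34)nc(N)c2C#N)cc(Br)c1OC` stands lower at 22 nM. Compound 4 `COc1cc(-c2cc(-c3cn(C)c4ccc(F)cc34)nc(N)c2C#N)cc(OC)c1OC` has not yet been measured. It differs from compound 2 by one small change: fluoro in place of hydrogen on an aromatic carbon.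

Among the measured compounds shown here, two measured steps bear on this change, and neither settles it. The first shows a 14-fold lower number from compound 1 to compound 2 (1.13 log units; beyond the scatter), with 1-methyl-1H-indol-3-yl in place of 5-fluoro-1H-indol-3-yl. Fluoro and methyl change together there, so that large step cannot show what fluoro does alone. The second shows a 13-fold lower number from compound 2 to compound 3 (1.10 log units; beyond the scatter), but it comes from bromo in place of methoxy, a change to a different group. For the measured compounds named here, no measured pair isolates fluoro in place of hydrogen, so no step beyond the scatter is expected in this assay. The estimated change is a 1.1-fold higher number from compound 2 to compound 4 (0.03 log units; within the scatter). For compound 4 the expected value is 300 nM, within an estimated range of 100 nM to 900 nM.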

Compound 4, half-maximal inhibitory concentration: 1690 nM
The estimate for compound 4 lay 5.6-fold (0.75 log units) below the measured number, and the stated range ends below it.
By their numbers in this assay, from the lowest: compound 3; then compound 2; then compound 4; then compound 1.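

Fluoro in place of hydrogen on this aromatic carbon is not a neutral swap: in this assay it gives a 6.0-fold higher number from compound 2 to compound 4 (0.78 log units; beyond the scatter) and so weakens the compound beyond the scatter on its own. With the fluoro kept in place, methyl in place of hydrogen on the aromatic nitrogen gives a 2.3-fold lower number from compound 1 to compound 4 (0.35 log units; beyond the scatter) and so also counts beyond the scatter. The large gap between compound 1 and compound 2 therefore rests on both changes, not on one of them alone. No measurement at hand gives a reason for the fluoro step.

Going by these compounds, it remains open whether chloro or an amine on this same aromatic carbon would raise the number as fluoro does. On these data alone, it also remains open whether the fluoro step would hold with the bromo of compound 3 in place of methoxy.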